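Working notes: amine chain extension from compound 3

The source may hold more compounds than are shown below. What is called first, only, known or untested is meant among the compounds shown, and "the series" means these compounds.

Measured compounds in a functional assay on RKO cells (Homo sapiens) for cytotoxicity, read by MTT assay, with a stated time of 48 h; a higher number here means a weaker inhibitor, a lower number a stronger inhibitor:
compound 1 `C=CCOc1ccc2c(NCCN(C)C)ccnc2c1`, 1270 nM
compound 2 `CN(C)CCCNc1ccnc2cc(OCc3ccc(F)cc3)ccc12`, 1230 nM
compound 3 `CCOc1ccc2c(NCCN(C)C)ccnc2c1`, 3650 nM

Compound 3 stands at the top of the three numbers in this assay. Going by the values given here, its nearest neighbour is compound 1, and the one measured step that connects them, a 2.9-fold higher number from compound 1 to compound 3 (0.46 log units; beyond the scatter), is a modest move upward. Among the compounds with values here, compound 2 sits at the low end, and its value and that of compound 3 differ by about as much; no single step links compound 2 to either of the others.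

Compound 4 `CCOc1ccc2c(NCCCN(C)C)ccnc2c1` differs from compound 3 by (dimethylamino)methyl in place of dimethylamino on a saturated chain carbon, two bonds along the chain from a nitrogen on an aromatic ring. Within the data shown here, none of the measured steps concerns this chain. Compound 2 carries the longer chain but also a different group on the oxygen, so its value shows only that a longer chain is compatible with a lower number in this assay, not what the chain alone does. Among the measured compounds shown here, with no step bearing directly on the change, the expected step of a 1.2-fold lower number from compound 3 to compound 4 (0.09 log units; within the scatter) is one within the scatter. Compound 4 is therefore estimated at 3000 nM in this assay, with a range from 1100 nM to 8000 nM.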

Compound 4, half-maximal inhibitory concentration: 5240 nM
Beside the measured number, compound 4's estimate is 1.7-fold (0.24 log units) below it; the measured number falls inside the stated range.
By their numbers in this assay, from the lowest: compounds 2 and 1 (each within the scatter of the next); then compounds 3 and 4 (each within the scatter of the next).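

In this assay, going by these compounds alone, the chain change on its own gives the first direct reading at this position (a 1.4-fold higher number from compound 3 to compound 4 (0.16 log units; within the scatter)), and it does not separate the (dimethylamino)methyl chain from the dimethylamino one. With the chain held constant, methyl in place of 4-fluorophenyl on the saturated chain carbon bound to an oxygen on an aromatic ring gives a step beyond the scatter (a 4.3-fold higher number from compound 2 to compound 4 (0.63 log units; beyond the scatter)), so in these two steps the number follows the group on the oxygen and not the chain. Nothing available accounts for either step.

Going by these compounds, whether the chain step reads the same when the oxygen carries the 4-fluorophenyl-bearing group remains open. Also open, on these data alone, is how a longer chain, such as 3-(dimethylamino)propyl, or a cyclic amine such as pyrrolidine at the chain end would read.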